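Dienone series: ring substituent swap from compound 3 to compound 4

The source may hold more compounds than are shown below. What is called first, only, known or untested is meant among the compounds shown, and "the series" means these compounds.

Working notes on a small set of aryl dienones built on a shared core. In a functional assay on HeLa cells (Homo sapiens) for cytotoxicity, read by sulforhodamine B assay, with a stated time of 48 h (on this read-out lower numbers stand for stronger inhibition and higher numbers for weaker inhibition), compound 1 `CC1=C(/C=C/C(=O)/C=C/c2ccc(Br)cc2)C(C)(C)CCC1` gives 88800 nM, compound 2 `CC1=C(/C=C/C(=O)/C=C/c2ccc(C)cc2)C(C)(C)CCC1` gives 20400 nM, and compound 3 `COc1ccccc1/C=C/C(=O)/C=C/C1=C(C)CCCC1(C)C` gives 88200 nM. Compound 3 thus stands second highest of the three numbers: its value and that of compound 1 lie within the scatter of each other, while the value of compound 2 sits clearly lower, beyond the scatter.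

The next compound is compound 4 `CC1=C(/C=C/C(=O)/C=C/c2ccccc2C)C(C)(C)CCC1`, which differs from compound 3 by methyl in place of methoxy on an aromatic carbon. Among the compounds with values here, the only measured step that bears on this change is a 4.4-fold lower number from compound 1 to compound 2 (0.64 log units; beyond the scatter), where a methyl also entered an aromatic carbon, though in place of a different group and at a different position, so it is an imperfect guide. Within the data shown here, no measured pair shows a methoxy leaving, so the size of that part of the change is not known from these data. On balance a modest move toward a lower number in this assay is expected, though a result within the scatter of compound 3 cannot be excluded. For compound 4 the expected step is a 2.5-fold lower number from compound 3 to compound 4 (0.40 log units; beyond the scatter). Compound 4 is therefore estimated at 35000 nM, with a range from 12000 nM to 100000 nM.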

Compound 4, half-maximal inhibitory concentration: > 100000 nM
Compound 4: a limit, no number; the forecaster's own chance of this, stated with the estimate: 5%; middle value at least 2.8-fold (0.45 log units) away from the limit.
By their numbers in this assay, from the lowest: compound 2; then compounds 3 and 1 (each within the scatter of the next). At a limit, above all of these: compound 4.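

Compound 4 gives > 100000 nM in this assay, which is a limit and not a number. Within the data shown here, the methyl that accompanied a lower number on going from the bromo compound 1 to compound 2 brings no such gain on the aromatic carbon ortho to a large group, and moving it there matters: an at least 4.9-fold higher number from compound 2 to compound 4 (0.69 log units; beyond the scatter), with 2-methylphenyl in place of 4-methylphenyl, is the one new step that can be read. The other two new steps, an at least 1.1-fold higher number from compound 3 to compound 4 (0.05 log units; that floor lies within the scatter) and an at least 1.1-fold higher number from compound 1 to compound 4 (0.05 log units; that floor lies within the scatter), have floors within the scatter and cannot be read as a separation, because the value of compound 4 has no upper end: the limit of > 100000 nM in this assay, at which 1 of the 4 values shown sits.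

On these data alone, how far compound 4 truly lies from compound 3 and compound 1 stays open, so it remains unsettled whether methoxy in compound 3 offers any advantage over methyl at this place. Also open, as far as these compounds go, is whether an amine or a carboxylic acid on this same aromatic carbon would give a number as low as that of compound 2, 20400 nM.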